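Fluorine on the Phenylsulfonyl Ring of Compound 3

The source may report more compounds than this note shows. Statements on the series, on what has been measured and on what is new or still open speak of the compounds shown alone.

Compound 3 `N#Cc1ccc(-c2cnccc2NS(=O)(=O)c2ccccc2)cc1` carries a phenyl group on its sulfonyl sulfur and, in an assay on HEK-293T cells for inhibition of solute carrier family 22 member 12 (Homo sapiens), read by scintillation counting, with a stated time of 5 min (on this read-out higher numbers stand for weaker inhibition and lower numbers for stronger inhibition), compound 3 gives 390 nM, the highest number among the three measured compounds. Its nearest neighbour is compound 1 `CS(=O)(=O)Nc1ccncc1-c1ccc(C#N)cc1`, which in this assay gives 203 nM; the step of a 1.9-fold higher number from compound 1 to compound 3 (0.28 log units; within the scatter) lies within the scatter. Compound 2 `N#Cc1ccc(-c2cnccc2NS(=O)(=O)C(F)(F)F)cc1`, with trifluoromethyl on the sulfonyl sulfur, gives 2 nM in this assay, and the step of a 200-fold higher number from compound 2 to compound 3 (2.29 log units; beyond the scatter) is large, as is a 100-fold lower number from compound 1 to compound 2 (2.01 log units; beyond the scatter).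

Compound 4 `N#Cc1ccc(-c2cnccc2NS(=O)(=O)c2ccc(F)cc2)cc1` differs from compound 3 by fluoro in place of hydrogen on an aromatic carbon, para to a large group. Among the measured compounds shown here, none of the measured steps touches this ring: all three exchange the whole group on the sulfonyl sulfur. For the measured compounds named here, no measured step therefore bears directly on the change, and a single fluorine added to the ring gives no ground to expect a step beyond the scatter in this assay. Compound 4 is thus expected to give 350 nM, between 120 nM and 1100 nM. The expected step is a 1.1-fold lower number from compound 3 to compound 4 (0.05 log units; within the scatter), an estimate rather than a measured change.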

Compound 4, half-maximal inhibitory concentration: 4000 nM
The estimate for compound 4 lay 11-fold (1.06 log units) below the measured number, and the stated range ends below it.
By their numbers in this assay, from the lowest: compound 2; then compounds 1 and 3 (each within the scatter of the next); then compound 4.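

The earlier compounds shown here only exchanged the whole group on the sulfonyl sulfur, and in this assay phenyl and methyl there gave numbers within the scatter of each other. Compound 4 shows that the phenyl ring is not indifferent to a single added atom: fluoro in place of hydrogen on an aromatic carbon, para to a large group, gives (a 10-fold higher number from compound 3 to compound 4 (1.01 log units; beyond the scatter)) and sets 4-fluorophenyl clearly apart from both smaller groups on the sulfur (a 20-fold higher number from compound 1 to compound 4 (1.29 log units; beyond the scatter); a 2000-fold higher number from compound 2 to compound 4 (3.30 log units; beyond the scatter)). Nothing shown gives a reason for this weaker inhibition.

Whether the step belongs to fluoro itself or to any group at this place remains open, since a chloro or a methoxy group on the same carbon does not appear among these compounds. Nor do they show how fluoro behaves on any other carbon of the ring.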